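Trimethoxyphenyl benzylamides: acyl group exchange on compound 1

This account rests on a few compounds, and the source may have more. Where it says the series, first, only, none or still open, it means among the compounds named here.

Measured so far:
compound 1 `C=C(C)C(=O)N(Cc1ccc(OC)c(O)c1)c1cc(OC)c(OC)c(OC)c1`, 200 nM
compound 2 `C/C=C/C(=O)N(Cc1ccc(OC)c(N)c1)c1cc(OC)c(OC)c(OC)c1`, 310 nM

Both compounds were tested in a functional assay on KYSE-450 cells (Homo sapiens) for inhibition, read by MTT assay, with a stated time of 48 h; on this read-out higher numbers stand for weaker inhibition and lower numbers for stronger inhibition. For the measured compounds named here, compound 1 gives the lower of the two numbers, but the gap to compound 2 lies within the usual scatter, so the two cannot be ranked, and no step between measured compounds is available to guide a prediction.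

Compound 3 `COc1ccc(CN(C(=O)CO)c2cc(OC)c(OC)c(OC)c2)cc1O` keeps the shared core of compound 1 and changes only the acyl group: hydroxymethyl in place of 1-methylethenyl on a carbonyl carbon. Going by the values given here, the pair compound 1 to compound 3 has no measured counterpart here, so the direction of the step must be estimated without a reference. Among the compounds with values here, a move toward a larger number in this assay is expected, beyond the scatter, because the only anchors are compound 1 at 200 nM and compound 2 at 310 nM, both carrying an unsaturated acyl group. For compound 3 the estimate is 1500 nM, range 300 nM to 8000 nM, a step of a 7.5-fold higher number from compound 1 to compound 3 (0.88 log units; beyond the scatter).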

Compound 3, half-maximal inhibitory concentration: 370 nM
Compound 3: the middle estimate sits 4.1-fold (0.61 log units) above what was measured, and the stated range covers the measured number.
By their numbers in this assay, from the lowest: compounds 1, 2 and 3 (each within the scatter of the next).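

In this assay the exchange of 1-methylethenyl for hydroxymethyl on a carbonyl carbon gives a 1.9-fold higher number from compound 1 to compound 3 (0.27 log units; within the scatter) and so leaves no difference that can be read at this position. Compounds 1 and 2 both carry an unsaturated acyl group, whereas compound 3 shows that a number of this order does not require a double bond outside aromatic rings in the acyl group, and that a group with a hydrogen-bond donor and acceptor can stand there. No measurement at hand accounts for this result.

Going by these compounds, whether an acyl group bearing an amine, a carboxylic acid or a longer chain would stay within the scatter of compound 1 remains open. Also open, on these data alone, is whether the same exchange on the core of compound 2 would give a similar step.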